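Para substituent effects on the shared anilinopyrimidine core

A few compounds are considered here, and "the series" means these few. Any claim that something is new, unique, unknown or untested is made for them only; others in the source may bear on it.

Compound 3 `c1ccc(Nc2nccc(-c3ccncc3)n2)cc1` gives 900 nM in a functional assay for inhibition, with Homo sapiens as the target (a higher number here means a weaker inhibitor, a lower number a stronger inhibitor), the lowest of the three numbers measured. Compound 1 `Fc1ccc(Nc2nccc(-c3ccncc3)n2)cc1` gives 1900 nM in this assay, and compound 2 `COc1ccc(Nc2nccc(-c3ccncc3)n2)cc1` gives 4200 nM. Compound 4 `c1cc(-c2ccnc(Nc3ccc(-n4ccnc4)cc3)n2)ccn1` differs from compound 3 by 1H-imidazol-1-yl in place of hydrogen on an aromatic carbon.

The relevant steps run the other way: a 2.1-fold lower number from compound 1 to compound 3 (0.32 log units; beyond the scatter) and a 4.7-fold lower number from compound 2 to compound 3 (0.67 log units; beyond the scatter), both removals of a group from the same place, both lowering the number. Placing a group at that position has therefore raised the number in each case seen, so a rise beyond the scatter is expected for compound 4, of about a 3.1-fold higher number from compound 3 to compound 4 (0.49 log units; beyond the scatter). Compound 4 is estimated at 2800 nM, within 900 nM to 9000 nM.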

Compound 4, half-maximal inhibitory concentration: 7600 nM
Compound 4: the middle estimate sits 2.7-fold (0.43 log units) below what was measured, within the range that was stated.
By their numbers in this assay, from the lowest: compound 3; then compound 1; then compounds 2 and 4 (each within the scatter of the next).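

In this assay, all three groups at this position, now including a five-membered aromatic ring, give a higher number than hydrogen, with an 8.4-fold higher number from compound 3 to compound 4 (0.93 log units; beyond the scatter) as the largest step in the series. Compared with fluoro, 1H-imidazol-1-yl gives a 4.0-fold higher number from compound 1 to compound 4 (0.60 log units; beyond the scatter) while compared with methoxy it gives a 1.8-fold higher number from compound 2 to compound 4 (0.26 log units; within the scatter) so these last two groups cannot be separated in this assay. Nothing available explains the size of these steps.

As far as these compounds go, whether any group at this position can bring the number below that of hydrogen remains open. An amine or a carboxylic acid there would test this.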